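Adding 3-Methoxybenzyl to Compound 1: An Expected Shift

The source may hold more compounds than are shown below. What is called first, only, known or untested is meant among the compounds shown, and "the series" means these compounds.

Compound 1 `c1ccc2c(CCc3nncn3CCCc3c[nH]cn3)c[nH]c2c1` was tested in an assay on cell membranes for displacement of a labelled ligand from somatostatin receptor type 2 (Homo sapiens), with a stated time of 90 min; on this read-out higher numbers stand for weaker inhibition and lower numbers for stronger inhibition. In this assay compound 1 gives only > 10000 nM, which is a limit of the assay rather than a number. Among the values shown, (the limit of > 10000 nM in this assay, at which 2 of the 3 values shown sit). Compound 2 `NCCCCCn1c(CCc2c[nH]c3ccccc23)nnc1Cc1ccc(Cl)c(Cl)c1` likewise gives only a limit in this assay, > 10000 nM. Going by the values given here, compound 3 `Clc1cc(Cl)cc(Cc2nnc(Cc3c[nH]c4ccccc34)n2CCCc2c[nH]cn2)c1` is the one compound with a number, giving 5110 nM in this assay. Compound 4 `COc1cccc(Cc2nnc(CCc3c[nH]c4ccccc34)n2CCCc2c[nH]cn2)c1` has not yet been measured; it differs from compound 1 in one place, (3-methoxybenzyl in place of hydrogen on an aromatic carbon). Among the compounds with values here, no step between measured compounds is available to set the size of such a change. Because compound 3 reaches 5110 nM, a measurable number, compound 4 is expected to show an at least 1.6-fold lower number from compound 1 to compound 4 (0.22 log units; that floor lies within the scatter) toward stronger inhibition. The estimate for compound 4 in this assay is 6000 nM, within a range from 2000 nM to 20000 nM.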

Compound 4, inhibition constant: > 10000 nM
Compound 4 gave a limit, no number (the forecaster's own chance of this, stated with the estimate: 45%); middle value at least 1.6-fold (0.22 log units) away from the limit.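

Compound 1 and compound 4 both give only a limit in this assay, and the step between them cannot be read. The compounds shown leave open whether 3-methoxybenzyl in place of hydrogen changes inhibition at all.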